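Opening the Fused Ring: What Compound 3 Might Dissolve To

The source may hold more compounds than are shown below. What is called first, only, known or untested is meant among the compounds shown, and "the series" means these compounds.

Compound 2 `CN1CCc2ncc(Nc3nnc(-c4cc(-c5cccnc5)cc(C(F)(F)F)c4)o3)cc2C1` stands highest of the two measured compounds in a physicochemical assay for solubility, read by HPLC, at pH 6.5 (on this read-out lower numbers stand for lower solubility and higher numbers for higher solubility), giving 68 ug/mL. Among the compounds with values here, its only measured neighbour, compound 1 `CN1CCc2ccc(Nc3nnc(-c4cc(-c5cccnc5)cc(C(F)(F)F)c4)o3)cc2C1`, gives 1.2 ug/mL; the step of a 57-fold higher number from compound 1 to compound 2 (1.75 log units; beyond the scatter) is the sole guide available. Compound 3 `CN(C)Cc1ccc(Nc2nnc(-c3cc(-c4cccnc4)cc(C(F)(F)F)c3)o2)cc1` alters the same position: a group of 10 heavy atoms (9 carbon, 1 nitrogen; one six-membered aromatic ring of carbon only) in place of a group of 11 heavy atoms (9 carbon, 2 nitrogen; one six-membered non-aromatic ring with 1 hetero atom, one six-membered aromatic ring with 1 hetero atom), on a nitrogen on an aromatic ring. The aromatic ring with one hetero atom that entered in the measured step now leaves, so a downward step is expected, though perhaps not all the way back to compound 1. Compound 3 is therefore expected to give 10 ug/mL, between 2 ug/mL and 50 ug/mL. The expected step is a 6.8-fold lower number from compound 2 to compound 3 (0.83 log units; beyond the scatter).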

Compound 3, solubility: 57 ug/mL
Compound 3: middle estimate off by 5.7-fold (0.76 log units), on the low side; measured number outside the range, above it.
By their numbers in this assay, from the lowest: compound 1; then compounds 3 and 2 (each within the scatter of the next).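

Placing 4-((dimethylamino)methyl)phenyl on the nitrogen gives a 1.2-fold lower number from compound 2 to compound 3 (0.08 log units; within the scatter), so at this position an aromatic ring of carbon only can match the number given by a ring with a hetero atom. The other new step, a 48-fold higher number from compound 1 to compound 3 (1.68 log units; beyond the scatter), shows that a carbon-only aromatic ring does not by itself bring the low number of compound 1, since 2-methyl-1,2,3,4-tetrahydroisoquinolin-7-yl and the opened group part widely here. No supporting measurement explains this difference. Still open, as far as these compounds go, is whether a morpholinomethyl or a longer 2-(dimethylamino)ethyl group on the same aromatic ring would give a similar number.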